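Methylsulfanyl in place of amino

The source may hold more compounds than are shown below. What is called first, only, known or untested is meant among the compounds shown, and "the series" means these compounds.

Measured compounds:
compound 1, `Nc1nccc2c1ncn2[C@H]1C[C@H](O)[C@@H](CO)O1`, 10 mg/kg
compound 2, `CSc1nccc2c1ncn2[C@H]1C[C@H](O)[C@@H](CO)O1`, > 9 mg/kg
compound 3, `Nc1[nH]ccc2ncnc1-2`, 8 mg/kg

In a functional assay on the whole organism (Pleural cavity) with Rattus norvegicus as the target (on this read-out lower numbers stand for an effect already at smaller amounts and higher numbers for an effect only at larger amounts of compound), compound 1 gives 10 mg/kg. Compound 2 gives only a limit, > 9 mg/kg, in this assay, and not a number. Compound 2 differs from compound 1 by methylsulfanyl in place of amino on an aromatic carbon. The step that the limit leaves unreadable from compound 1 to compound 2 therefore cannot be sized, because of the limit of > 9 mg/kg in this assay, at which 1 of the 3 values shown sits.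

Compound 3 carries a different core, and in this assay compound 3 gives 8 mg/kg, which sits within the scatter of the value of compound 1. The difference between the two cores is not broken down here.

Compound 4, `CSc1[nH]ccc2ncnc1-2`, has not yet been measured in this assay. Compound 4 differs from compound 3 by methylsulfanyl in place of amino on an aromatic carbon, the same change as from compound 1 to compound 2, at the same kind of place. Among the measured compounds shown here, since the only measured instance of this change ends in a limit, the expectation for compound 4 rests on little: the change did not make compound 2 readably more potent than compound 1, and may have weakened it. Compound 4 is therefore expected to sit near or somewhat above compound 3, an estimated step of a 1.9-fold higher number from compound 3 to compound 4 (0.27 log units; within the scatter), with a real chance that only a limit is obtained. The estimate for compound 4 in this assay is 15 mg/kg, expected between 7 mg/kg and 40 mg/kg.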

Compound 4, dose for half-maximal effect: 9 mg/kg
For compound 4 the middle estimate is 1.7-fold (0.22 log units) above the measured one; the measured number falls inside the stated range.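

In this assay, putting methylsulfanyl in place of amino on the core of compound 3 gives a 1.1-fold higher number from compound 3 to compound 4 (0.05 log units; within the scatter), and this one readable instance shows no difference between the two groups on that core beyond the usual scatter. On the core of compound 1, compound 2 gives only a limit and not a number, and the matching step therefore cannot be read: the limit of > 9 mg/kg in this assay, at which 1 of the 4 values shown sits. With only one of the two instances giving a size, the account can neither confirm nor refute that the change carries from one core to the other with a similar size, and it offers no general rule for the series.

The compounds shown leave open how other groups on this aromatic carbon would read in this assay, for instance a longer chain such as ethylsulfanyl, a methoxy group, or a carboxylic acid. They also leave open how far compound 2 actually lies from compound 1, which a limit cannot tell, and with it whether the change has the same size on both cores.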